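The source may report more compounds than this note shows. Statements on the series, on what has been measured and on what is new or still open speak of the compounds shown alone.

Working notes on the series. Compound 2 `Nc1ncnc2c1ccn2-c1ccc(NC(=O)c2ccc(Cl)c(C(F)(F)F)c2)cc1` gives 5600 nM in an ADME assay on HS27 cells (Homo sapiens) for antiproliferative activity, read by MTT assay, with a stated time of 24 h; on this read-out higher numbers stand for weaker inhibition and lower numbers for stronger inhibition. Compound 1 `O=C(Nc1ccc(-n2ccc3c(NC(=O)c4ccccc4)ncnc32)cc1)c1ccc(Cl)c(C(F)(F)F)c1` carries benzoyl in place of hydrogen on a nitrogen on an aromatic ring relative to compound 2, and in this assay compound 1 gives 5500 nM, the step being a 1.0-fold lower number from compound 2 to compound 1 (0.01 log units; within the scatter). Compound 3 `Nc1ncnc2c1ccn2-c1ccc(NC(=O)c2cccc(C(F)(F)F)c2)cc1` gives 7100 nM in this assay, a step of a 1.3-fold higher number from compound 2 to compound 3 (0.10 log units; within the scatter); the three values sit close together and no ordering is drawn from them.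

Compound 4 `O=C(Nc1ccc(-n2ccc3c(NC(=O)c4ccccc4)ncnc32)cc1)c1cccc(C(F)(F)F)c1` is not yet measured. It differs from compound 3 by benzoyl in place of hydrogen on a nitrogen on an aromatic ring, the same change as that from compound 2 to compound 1, at a place described in identical terms. The two cores differ by hydrogen in place of chloro on an aromatic carbon. Because a 1.0-fold lower number from compound 2 to compound 1 (0.01 log units; within the scatter) fell within the scatter, the step from compound 3 to compound 4 is expected to be a 1.0-fold lower number from compound 3 to compound 4 (0.01 log units; within the scatter), also within the scatter. Compound 4 is accordingly estimated at 7000 nM in this assay, with a likely range from 3500 nM to 14000 nM.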

Compound 4, half-maximal inhibitory concentration: 5900 nM
The estimate for compound 4 lay 1.2-fold (0.07 log units) above the measured number, within the range that was stated.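

Benzoyl in place of hydrogen on a nitrogen on an aromatic ring gives a 1.2-fold lower number from compound 3 to compound 4 (0.08 log units; within the scatter), and in this assay the step carries from one core to the other without a discernible difference: the same change on two cores in this assay, a 1.0-fold lower number (0.01 log units; within the scatter) from compound 2 to compound 1 and a 1.2-fold lower number (0.08 log units; within the scatter) from compound 3 to compound 4, 1.2-fold (0.07 log units) apart, within the scatter of two such steps

Hydrogen in place of chloro on an aromatic carbon gives a 1.1-fold higher number from compound 1 to compound 4 (0.03 log units; within the scatter), and it carries over in the same way: the same change on two cores in this assay, a 1.3-fold higher number (0.10 log units; within the scatter) from compound 2 to compound 3 and a 1.1-fold higher number (0.03 log units; within the scatter) from compound 1 to compound 4, 1.2-fold (0.07 log units) apart, within the scatter of two such steps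

Going by these compounds alone, every one of these steps lies within the scatter, so the agreement shows only that neither change moves the number on these two cores in this one assay, and it does not show that a change with a real effect would carry over between cores.

Open, going by these compounds, is whether acetyl or a longer acyl chain in place of benzoyl would give a step beyond the scatter. Also open, on these data alone, is whether an amine or a carboxylic acid in place of chloro would do so.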